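Swapping a benzothiophene for an indole on an aminopyrimidine

A few compounds are considered here, and "the series" means these few. Any claim that something is new, unique, unknown or untested is made for them only; others in the source may bear on it.

Two members of this series have been measured in a functional assay on K562 cells (Homo sapiens) for inhibition, read by trypan blue exclusion, with a stated time of 72 h; on this read-out lower numbers stand for stronger inhibition and higher numbers for weaker inhibition. Compound 1, with the structure `Cn1c(=O)c(S(=O)(=O)c2ccc(F)cc2F)cc2cnc(Nc3ccc4sccc4c3)nc21`, gives 500 nM, the lowest of the two numbers. Compound 2, with the structure `Cn1c(=O)c(S(=O)(=O)Nc2ccc(F)cc2)cc2cnc(Nc3ccc4[nH]ccc4c3)nc21`, gives 5000 nM, a weaker result; it differs from compound 1 in more than one place, so the two values say nothing about any single change.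

Compound 3, with the structure `Cn1c(=O)c(S(=O)(=O)c2ccc(F)cc2F)cc2cnc(Nc3ccc4cc[nH]c4c3)nc21`, has not yet been measured in this assay. It differs from compound 1 in one place: 1H-indol-6-yl in place of 1-benzothiophen-5-yl on a nitrogen on an aromatic ring. Among the measured compounds shown here, both groups are fused aromatic rings of the same size, and the only measured comparison in this set does not isolate this change. The step from compound 1 to compound 3 is therefore expected to be small, likely within the usual scatter, with a slight lean toward weaker inhibition: a 1.6-fold higher number from compound 1 to compound 3 (0.20 log units; within the scatter). Compound 3 is estimated at 800 nM, in the range from 250 nM to 2500 nM.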

Compound 3, half-maximal inhibitory concentration: 5000 nM
Beside the measured number, compound 3's estimate is 6.3-fold (0.80 log units) below it; the whole stated range lies below it.
By their numbers in this assay, from the lowest: compound 1; then compounds 2 and 3 (each within the scatter of the next).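

In this assay, 1H-indol-6-yl in place of 1-benzothiophen-5-yl on the nitrogen gives a 10-fold higher number from compound 1 to compound 3 (1.00 log units; beyond the scatter), so this position is sensitive to which fused aromatic group it carries, even though both groups have the same ring sizes and the same number of heavy atoms. The earlier pair could not show this, as compound 1 and compound 2 differ in more than one place, but this single step still bundles several differences: sulfur gives way to a ring nitrogen bearing hydrogen, the hydrogen-bond counts change, and the attachment changes from 5-yl to 6-yl. No available evidence explains the size of this step.

Which of these differences matters remains open. Results for 1-benzofuran-5-yl and 1-benzothiophen-6-yl on the core of compound 1 would help separate the ring atom from the attachment point.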